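Pentan-3-yl replaces 3-fluoropropyl in a two-compound series

A few compounds are considered here, and "the series" means these few. Any claim that something is new, unique, unknown or untested is made for them only; others in the source may bear on it.

The series rests on a shared core carrying a chlorine and an amino group on the aromatic system. Compound 1 `O[C@@H]1[C@H](O)[C@@H]2C[C@@H]2[C@H]1n1cnc2c(NC3CCCCCCC3)nc(Cl)nc21` bears a cyclooctyl group on that nitrogen, and in an assay on CHO cells for displacement of a labelled ligand from adenosine receptor A1 (Homo sapiens), read by scintillation counting, with a stated time of 60 min (on this read-out lower numbers stand for stronger inhibition and higher numbers for weaker inhibition), compound 1 gives 760 nM. Within the data shown here, compound 2 `O[C@@H]1[C@H](O)[C@@H]2C[C@@H]2[C@H]1n1cnc2c(NCCCF)nc(Cl)nc21` carries a 3-fluoropropyl group there, and in this assay compound 2 gives 72.7 nM, the lower of the two numbers; the only step measured so far is a 10-fold lower number from compound 1 to compound 2 (1.02 log units; beyond the scatter). Compound 3 `CCC(CC)Nc1nc(Cl)nc2c1ncn2[C@H]1[C@H](O)[C@H](O)[C@@H]2C[C@@H]21` introduces a further change at the same place: pentan-3-yl in place of 3-fluoropropyl on a nitrogen on an aromatic ring. Among the measured compounds shown here, the one measured step shows that a bulky ring on this nitrogen gives a weaker number than a short fluorinated chain; pentan-3-yl is a branched chain without a ring, so no step beyond the scatter is expected from compound 2 to compound 3, though the direction remains uncertain. For compound 3 the estimate in this assay is 150 nM, within 40 nM to 600 nM, corresponding to a 2.1-fold higher number from compound 2 to compound 3 (0.31 log units; beyond the scatter).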

Compound 3, inhibition constant: 78.8 nM
For compound 3 the middle estimate is 1.9-fold (0.28 log units) above the measured one, within the range that was stated.
By their numbers in this assay, from the lowest: compounds 2 and 3 (each within the scatter of the next); then compound 1.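

In this assay, pentan-3-yl in place of 3-fluoropropyl on this nitrogen gives a 1.1-fold higher number from compound 2 to compound 3 (0.03 log units; within the scatter) and so leaves the number where it was: a branched chain of carbon alone matches the fluorinated straight chain here. Cyclooctyl now stands apart from two different open chains rather than one, as pentan-3-yl in its place gives a 9.6-fold lower number from compound 1 to compound 3 (0.98 log units; beyond the scatter) and thus nearly the same drop as 3-fluoropropyl did. Nothing available explains why these groups behave as they do.

As far as these compounds go, whether the ring itself or only its size sets cyclooctyl apart remains open, and a cyclopentyl group on this nitrogen would bear on that. A plain propyl chain would show whether the fluorine matters at all in the straight chain.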